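Swapping the piperazine substituent of a Toll-like receptor 8 agonist

A few compounds are considered here, and "the series" means these few. Any claim that something is new, unique, unknown or untested is made for them only; others in the source may bear on it.

Three analogues sharing one core have been measured in an assay on HEK293 cells for agonist activity at Toll-like receptor 8 (Homo sapiens), read by spectrophotometry; a higher number here means that more compound is needed for the effect, a lower number that less compound is needed. Compound 1 `CCCCNc1nc(N)nc(C)c1CCCN1CCCCCC1` gives 178 nM, compound 2 `CCCCNc1nc(N)nc(C)c1CCCN(CC)CC` gives 254 nM, and compound 3 `CCCCNc1nc(N)nc(C)c1CCCN1CCN(c2ccccc2)CC1` gives 92 nM, the lowest of the three numbers; its nearest neighbour is compound 1 and its furthest is compound 2. Within the data shown here, the one step between measured compounds, a 1.4-fold higher number from compound 1 to compound 2 (0.15 log units; within the scatter), lies within the scatter. Compound 4 `CCCCNc1nc(N)nc(C)c1CCCN1CCN(C)CC1` differs from compound 3 by methyl in place of phenyl on an amine nitrogen in a ring. Among the measured compounds shown here, no measured step touches the ring nitrogen itself, and the only amine change seen moved the number little, so a modest rise in this assay is expected, a 1.6-fold higher number from compound 3 to compound 4 (0.21 log units; within the scatter). Compound 4 is thus estimated at 150 nM, between 60 nM and 400 nM.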

Compound 4, half-maximal effective concentration: 179 nM
The estimate for compound 4 lay 1.2-fold (0.08 log units) below the measured number; measured number inside the range.
By their numbers in this assay, from the lowest: compounds 3, 1, 4 and 2 (each within the scatter of the next, the first and the last beyond it).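

In this assay, methyl in place of phenyl on the amine nitrogen in the ring gives a 1.9-fold higher number from compound 3 to compound 4 (0.29 log units; within the scatter), so the aromatic ring is not shown to be needed at this position. The other two steps, a 1.4-fold lower number from compound 2 to compound 4 (0.15 log units; within the scatter) and a 1.0-fold higher number from compound 1 to compound 4 (0.00 log units; within the scatter), show that 4-methylpiperazin-1-yl on the chain cannot be told apart from diethylamino or azepan-1-yl. Nothing available accounts for these numbers. As far as these compounds go, it remains open whether a benzyl group, an acetyl group or a plain hydrogen on that nitrogen would give a step beyond the scatter.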